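The source may report more compounds than this note shows. Statements on the series, on what has been measured and on what is new or still open speak of the compounds shown alone.

In a functional assay on HCT-116 cells (Homo sapiens) for antiproliferative activity, read by MTT assay, with a stated time of 72 h (a lower number here means a stronger inhibitor, a higher number a weaker inhibitor), three compounds built on one shared core have been measured. Compound 1 `O=C(CCc1cccc2c1B(O)OC2)NCc1ccccc1` reaches only a limit of the assay, > 100000 nM. Compound 2 `O=C(CCc1cccc2c1B(O)OC2)Nc1ccc(F)cc1` gives 650 nM. Compound 3 `O=C(CCc1cccc2c1B(O)OC2)Nc1ccc(Cl)cc1` gives 12000 nM, the higher of the two true numbers, and compound 2 is its nearest neighbour.

Compound 4 `O=C(CCc1cccc2c1B(O)OC2)Nc1ccc(Br)cc1` differs from compound 3 in one place: bromo in place of chloro on an aromatic carbon, para to a large group (bromo in place of chloro on an aromatic carbon). The most relevant measured change is the other swap at this position, an 18-fold higher number from compound 2 to compound 3 (1.27 log units; beyond the scatter), which was large and raised the number. The steps of an at least 150-fold lower number from compound 1 to compound 2 (2.18 log units; beyond the scatter) and an at least 8.3-fold lower number from compound 1 to compound 3 (0.92 log units; beyond the scatter) replace benzyl on the amide-type nitrogen, so they bear on the new change only indirectly. A single halogen swap does not establish a trend, so the estimate stays close to compound 3 at 12000 nM, with any drift expected to be upward. The expected step is a 1.3-fold higher number from compound 3 to compound 4 (0.10 log units; within the scatter), which is not expected to exceed the scatter. For compound 4, the estimated value in this assay is 15000 nM, with an expected range of 3000 nM to 60000 nM.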

Compound 4, half-maximal inhibitory concentration: 46000 nM
Compound 4: the middle estimate sits 3.1-fold (0.49 log units) below what was measured; measured number inside the range.
By their numbers in this assay, from the lowest: compound 2; then compound 3; then compound 4. At a limit, above all of these: compound 1.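

In this assay, the bromo swap shows that the rise seen on going from fluoro to chloro was not a single jump: a 3.8-fold higher number from compound 3 to compound 4 (0.58 log units; beyond the scatter), and the full span across this halogen position is a 71-fold higher number from compound 2 to compound 4 (1.85 log units; beyond the scatter). Among the three halogens, the number therefore climbs in the order fluoro, chloro, bromo, with no compound going against that order, although the second swap is the smaller of the two. The bromo compound still keeps a lower number than the benzyl amide, an at least 2.1-fold lower number from compound 1 to compound 4 (0.33 log units; beyond the scatter), but this step is only a bound, since compound 1 stands at a limit of the assay: the limit of > 100000 nM in this assay, at which 1 of the 4 values shown sits.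

From the compounds shown here alone, whether the climb continues to iodo remains open, as does what an unsubstituted phenyl or a methoxy group would give. Also open, going by these compounds, is whether the same halogen order holds with a longer chain between the shared core and the amide carbonyl.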